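The compounds below may be only part of what the source reports. "The series", "measured", "known", "first", "only" and "open" are said of these compounds alone.

Two compounds from this series carry a measured value. Compound 1, `Cc1n[nH]c2ccc(-c3nc4cnc(N5CCC(C)CC5)cn4c3Nc3ccc(Cl)cc3)cc12`, gives 12.6% in a functional assay on CWR22R cells (Homo sapiens) for inhibition, with a stated time of 120 h, tested at 10 uM; a higher number here means more inhibition at the concentration tested (going by the name of the read-out), a lower number less inhibition. Compound 2, `COc1ccc(Nc2c(-c3ccc4[nH]nc(C)c4c3)nc3cnc(N4CCN(C)CC4)cn23)cc1`, gives 0% in this assay, which is the lowest of the two numbers; the nearest is compound 1, whose number lies higher by a margin beyond the usual scatter of repeated measurements. Within the data shown here, no step between two measured compounds that differ in a single place has been worked out, so the effect of any one change is not yet known from the data.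

Compound 3, `Cc1n[nH]c2ccc(-c3nc4cnc(N5CCN(C)CC5)cn4c3Nc3ccc(F)c(Cl)c3)cc12`, has not been measured in this assay. It differs from compound 2 in one place: 3-chloro-4-fluorophenyl in place of 4-methoxyphenyl on a nitrogen on an aromatic ring. As compound 2 reads 0%, the only room is upward or none beyond the scatter. In this assay the step from compound 2 to compound 3 is expected to be a number 8 percentage points higher from compound 2 to compound 3 (within the scatter), a small gain that does not clearly exceed the scatter. Compound 3 is therefore estimated at 8%, within a range from 0% to 25%.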

Compound 3, a percentage reported as inhibition, at one concentration (the size of the read-out at that concentration, not a potency): 0.82%
For compound 3 the middle estimate is 7.2 percentage points above the measured one; the measured number falls inside the stated range.
By their numbers in this assay, from the lowest: compounds 2 and 3 (each within the scatter of the next); then compound 1.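

Among these compounds, at this position, on a nitrogen on an aromatic ring, the exchange of 4-methoxyphenyl for 3-chloro-4-fluorophenyl gives the first single change that can be read, and in this assay it amounts to a number 0.8 percentage points higher from compound 2 to compound 3 (within the scatter). The two groups differ in what they carry, since a methoxy oxygen leaves and a fluorine and a chlorine enter, yet this change leaves the read-out within the scatter, and both compounds sit at the low end of the scale at the one concentration tested, so a real difference between them could remain hidden there. No measurement at hand offers an explanation for this result.

Compound 1 differs from compound 2 and from compound 3 in more than one place, so its higher number cannot be assigned to the group on this nitrogen or to any other single change. Still open, as far as these compounds go, is whether a quite different group at this position, such as an unsubstituted phenyl, a pyridyl ring or a benzyl group, would move the number clearly beyond the scatter in this assay.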